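The source may report more compounds than this note shows. Statements on the series, on what has been measured and on what is new or still open speak of the compounds shown alone.

Compound 1, `Cc1c(Oc2cnc(C(=O)NCCO)cn2)ccc2c1B(O)OC2`: 31400 ng.h/mL
Compound 2, `Cc1c(Oc2cnc(C(=O)NC(C)CO)cn2)ccc2c1B(O)OC2`: 39000 ng.h/mL

In an ADME assay on the whole organism (strain CD1) for pharmacokinetics, with Mus musculus as the target, read by LC-MS, at a dose of 5 mg/kg by the intravenous route (a higher number here means more compound in the circulation at the dose given, a lower number less compound in the circulation), compound 2 gives 39000 ng.h/mL, and in the same assay compound 1 gives 31400 ng.h/mL; the two numbers lie within the scatter of each other, so compound 2 stands alongside compound 1 rather than apart from it. Compound 3, `Cc1c(Oc2cnc(C(=O)N3CC(C)(O)C3)cn2)ccc2c1B(O)OC2`, differs from compound 2 in one place: 3-hydroxy-3-methylazetidin-1-yl in place of (1-(hydroxymethyl)ethyl)amino on a carbonyl carbon. Going by the values given here, the only measured step, a 1.2-fold higher number from compound 1 to compound 2 (0.09 log units; within the scatter), also touched the group on the amide-type nitrogen and stayed within the scatter. Among the compounds with values here, that step bears on compound 3 only loosely, since here a chain gives way to a ring and one hydrogen-bond donor is lost, which no measured pair covers. Compound 3 is therefore expected to give about 35000 ng.h/mL, in a range from 15000 ng.h/mL to 75000 ng.h/mL. The step this estimate means, a 1.1-fold lower number from compound 2 to compound 3 (0.05 log units; within the scatter), is expected to stay within the scatter.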

Compound 3, area under the concentration-time curve: 20500 ng.h/mL
Beside the measured number, compound 3's estimate is 1.7-fold (0.23 log units) above it; the measured number falls inside the stated range.
By their numbers in this assay, from the lowest: compounds 3, 1 and 2 (each within the scatter of the next).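

The earlier compounds shown here varied only a chain on the amide nitrogen, whereas compound 3 puts a four-membered ring on the carbonyl carbon. In this assay, 3-hydroxy-3-methylazetidin-1-yl in place of (1-(hydroxymethyl)ethyl)amino gives a 1.9-fold lower number from compound 2 to compound 3 (0.28 log units; within the scatter), and in place of (2-hydroxyethyl)amino it gives a 1.5-fold lower number from compound 1 to compound 3 (0.19 log units; within the scatter), so this position takes a ring as well as a chain without a step beyond the scatter, even with one hydrogen-bond donor fewer than in compound 2. Nothing available accounts for these numbers.

All three groups at this position carry a hydroxyl, which leaves open how an amine, a carboxylic acid or a longer chain would read here. A larger ring, such as piperidine, also remains an open question on this carbonyl carbon.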